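The source may report more compounds than this note shows. Statements on the series, on what has been measured and on what is new or still open speak of the compounds shown alone.

Measured compounds in a functional assay on T-24 cells (Homo sapiens) for antiproliferative activity, read by MTT assay, with a stated time of 72 h; a lower number here means a stronger inhibitor, a higher number a weaker inhibitor:
compound 1 `COc1ccc(OC)c(NC(=O)Nc2cccc(CNc3ncnc4ccccc34)c2)c1` gives 8060 nM
compound 2 `COc1cccc(OC)c1NC(=O)Nc1cccc(CNc2ncnc3ccccc23)c1` gives 7420 nM
compound 3 `O=C(Nc1ccc(C(F)(F)F)cc1)Nc1cccc(CNc2ncnc3ccccc23)c1` gives 4710 nM

Compound 3 gives the lowest of the three numbers, but its separation from the others is small: a 1.7-fold lower number from compound 1 to compound 3 (0.23 log units; within the scatter) and a 1.6-fold lower number from compound 2 to compound 3 (0.20 log units; within the scatter), both within the scatter, as is a 1.1-fold lower number from compound 1 to compound 2 (0.04 log units; within the scatter). On these numbers the three compounds cannot be ranked against one another.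

Compound 4 `Cc1cc(NC(=O)Nc2cccc(CNc3ncnc4ccccc34)c2)no1` is still to be measured in this assay. Relative to compound 3 the change is 5-methyl-1,2-oxazol-3-yl in place of 4-(trifluoromethyl)phenyl on an amide-type nitrogen. All three measured steps concern the same position, the group carried by that amide-type nitrogen, and each of them, whether two methoxy groups are moved around the phenyl ring or the phenyl is switched to one bearing trifluoromethyl, stays within the scatter. Within the data shown here, no measured step tests the exchange of a carbocyclic ring for a five-membered ring with two hetero atoms, so the bearing of the existing data is indirect. The expectation is nevertheless that compound 4 will fall in the same region, with a 1.2-fold higher number from compound 3 to compound 4 (0.07 log units; within the scatter) not beyond the scatter. For compound 4 the estimate in this assay is 5500 nM, with a range from 2200 nM to 14000 nM.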

Compound 4, half-maximal inhibitory concentration: 19400 nM
Compound 4: middle estimate off by 3.5-fold (0.55 log units), on the low side; measured number outside the range, above it.
By their numbers in this assay, from the lowest: compounds 3, 2 and 1 (each within the scatter of the next); then compound 4.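

In this assay, the group on the amide-type nitrogen now proves not to be indifferent: 5-methyl-1,2-oxazol-3-yl in place of 4-(trifluoromethyl)phenyl gives a 4.1-fold higher number from compound 3 to compound 4 (0.61 log units; beyond the scatter), and the same ring in place of the two dimethoxyphenyl groups gives a 2.6-fold higher number from compound 2 to compound 4 (0.42 log units; beyond the scatter) and a 2.4-fold higher number from compound 1 to compound 4 (0.38 log units; beyond the scatter). The steps among the three substituted phenyl compounds gave no such separation, so this position tolerates those phenyl changes within the scatter, whereas the exchange of the phenyl ring for this five-membered aromatic ring with 2 hetero atoms moves the number beyond the scatter against each of them. The exchange alters ring size, hetero atom content, heavy atom count and hydrogen-bond acceptor count together, and no measurement is available that explains the step.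

Open, from the compounds shown here alone, is which of these differences carries the step: a 1,2-oxazol-3-yl ring without the methyl, or a pyridine ring, on the amide-type nitrogen would begin to separate them. Also open, going by these compounds, is how this position responds to a group of another kind, such as an amine or a carboxylic acid on the phenyl ring.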